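Nitro for cyano on the fused chromene core

The source may report more compounds than this note shows. Statements on the series, on what has been measured and on what is new or still open speak of the compounds shown alone.

Measured so far in a functional assay (aorta) with Rattus norvegicus as the target; a lower number here means that less compound is needed, a higher number that more compound is needed for the effect:
compound 1 `N#Cc1ccc2c(c1)C(N1CCCC1=O)=CC(CF)(CF)O2` — 102 nM
compound 2 `O=C1CCCN1C1=CC(CF)(CF)Oc2ccc([N+](=O)[O-])cc21` — 7.76 nM
compound 3 `N#Cc1ccc2c(c1)C(n1ccccc1=O)=CC(CF)(CF)O2` — 24.6 nM

Compound 1 and compound 2 differ only in the change (nitro in place of cyano on an aromatic carbon). That change gave a 13-fold lower number from compound 1 to compound 2 (1.12 log units; beyond the scatter).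

Compound 3 shares the core of compound 1 but differs in the change (a group of 7 heavy atoms (5 carbon, 1 nitrogen, 1 oxygen; one six-membered aromatic ring with 1 hetero atom) in place of a group of 6 heavy atoms (4 carbon, 1 nitrogen, 1 oxygen; one five-membered non-aromatic ring with 1 hetero atom), on a double-bonded ring carbon), which gave a 4.1-fold lower number from compound 1 to compound 3 (0.62 log units; beyond the scatter). Compound 3 stands second among the three values; compound 2 gives the lower number of the two, and the two values lie beyond the scatter of each other.

Compound 4 `O=c1ccccn1C1=CC(CF)(CF)Oc2ccc([N+](=O)[O-])cc21` is not yet measured. It differs from compound 3 in the change (nitro in place of cyano on an aromatic carbon). The place of this change is the same, word for word, as for the change from compound 1 to compound 2, so it is the same change, made here on the core of compound 3. The step from compound 3 to compound 4 in this assay is expected to be of a size close to the earlier one, because compound 1 to compound 2 gave a 13-fold lower number from compound 1 to compound 2 (1.12 log units; beyond the scatter); a single precedent is all that supports this, so the expected range is kept wide. From this, compound 4 is expected to give about 2.5 nM, between 0.8 nM and 8 nM, that is an estimated step of a 9.8-fold lower number from compound 3 to compound 4 (0.99 log units; beyond the scatter).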

Compound 4, half-maximal effective concentration: 2.46 nM
Estimate against measurement, compound 4: 1.0-fold (0.01 log units) above; the measured number falls inside the stated range.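

In this assay, nitro in place of cyano on an aromatic carbon gives a 10-fold lower number from compound 3 to compound 4 (1.00 log units; beyond the scatter), and this step agrees with the one seen on the other core: the same change on two cores in this assay, a 13-fold lower number (1.12 log units; beyond the scatter) from compound 1 to compound 2 and a 10-fold lower number (1.00 log units; beyond the scatter) from compound 3 to compound 4, 1.3-fold (0.12 log units) apart, within the scatter of two such steps. The exchange of rings on the double-bonded ring carbon also carries over, giving a 3.2-fold lower number from compound 2 to compound 4 (0.50 log units; beyond the scatter) with nitro on the aromatic carbon: the same change on two cores in this assay, a 4.1-fold lower number (0.62 log units; beyond the scatter) from compound 1 to compound 3 and a 3.2-fold lower number (0.50 log units; beyond the scatter) from compound 2 to compound 4, 1.3-fold (0.12 log units) apart, within the scatter of two such steps. Across these four compounds the two changes therefore combine as if independent, but this rests on one pair of steps for each change and shows neither why the numbers fall nor whether the agreement would hold on other cores.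

Open, as far as these compounds go, is whether the same carry-over extends to other groups on that aromatic carbon, such as an amine or a carboxylic acid. Also open, from the compounds shown here alone, is how a longer chain in place of either ring on the double-bonded ring carbon would behave in this assay.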